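Cytotoxicity of three fluorophenyl amides and a chloro analogue

A few compounds are considered here, and "the series" means these few. Any claim that something is new, unique, unknown or untested is made for them only; others in the source may bear on it.

The series shares one core, carried by compound 1 `O=C(Nc1ccccc1F)c1ccc2cccc(O)c2n1`, compound 2 `O=C(Nc1cccc(F)c1)c1ccc2cccc(O)c2n1` and compound 3 `O=C(Nc1ccc(F)cc1)c1ccc2cccc(O)c2n1`, and is read in an ADME assay on THP-1 cells (Homo sapiens) for cytotoxicity, read by WST assay, with a stated time of 24 h; on this read-out higher numbers stand for weaker inhibition and lower numbers for stronger inhibition. In this assay compound 1 gives only a limit, > 30000 nM. Compound 2 likewise reaches only a limit, > 30000 nM. Compound 3 also stops at a limit, > 30000 nM. The steps a step that the two limits leave unreadable from compound 1 to compound 2, a step that the two limits leave unreadable from compound 1 to compound 3 and a step that the two limits leave unreadable from compound 2 to compound 3 therefore cannot be sized, since all three values sit at the limit of > 30000 nM in this assay, at which 3 of the 3 values shown sit. Compound 3 thus stands where every measured compound stands, at the limit. Compound 4 `O=C(Nc1cccc(Cl)c1)c1ccc2cccc(O)c2n1` differs from it by 3-chlorophenyl in place of 4-fluorophenyl on an amide-type nitrogen. For the measured compounds named here, no measured step reports a readable size, so the data give no direction for this change. Compound 4 is therefore expected to stay at the limit as well, with a step of a number no higher from compound 3 to compound 4 (the limit leaves the size open), and its estimated value is 30000 nM within 10000 nM to 100000 nM.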

Compound 4, half-maximal inhibitory concentration: > 30000 nM
Compound 4: a limit, no number; the forecaster's own chance of this, stated with the estimate: 85%; the middle value lies on the limit itself.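

For the compounds shown here, compound 4 also gives only a limit in this assay, so no step linking it to compound 1, compound 2 or compound 3 can be read: the limit of > 30000 nM in this assay, at which 4 of the 4 values shown sit. The compounds shown leave open how far each lies from that limit and whether any change on the amide-type nitrogen alters the read-out.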